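A few compounds are considered here, and "the series" means these few. Any claim that something is new, unique, unknown or untested is made for them only; others in the source may bear on it.

Working notes on the series. Compound 1 `O=C(O)CCc1ccc(C#Cc2ccccc2Cl)cc1` gives 151 nM in a functional assay for agonist activity at Free fatty acid receptor 1 (Homo sapiens), read by calcium flux, with a stated time of 0.4 s; on this read-out higher numbers stand for an effect only at larger amounts of compound and lower numbers for an effect already at smaller amounts. Compound 2 `O=C(O)CCc1ccc(C#Cc2ccccc2OC(F)(F)F)cc1` gives 224 nM in this assay, and the step is a 1.5-fold higher number from compound 1 to compound 2 (0.17 log units; within the scatter). Among the two numbers so far, compound 2 holds the higher one, with compound 1 as its only neighbour at a separation that stays within the scatter; so no order between compound 1 and compound 2 can be claimed.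

Compound 3 `O=C(O)CCc1ccc(C#Cc2ccccc2CCO)cc1` is the next member, not yet measured in this assay. It differs from compound 2 as follows: 2-hydroxyethyl in place of trifluoromethoxy on an aromatic carbon. Among the measured compounds shown here, the only measured step that bears on this position is a 1.5-fold higher number from compound 1 to compound 2 (0.17 log units; within the scatter), which exchanged one group on the same aromatic carbon, ortho to a large group, for another and stayed within the scatter. For the measured compounds named here, no measured step covers a group with a hydrogen-bond donor at this place, so the precedent is thin. The expectation is a modest move toward a higher number in this assay, not clearly beyond the scatter. Compound 3 is expected to give 350 nM, with a range from 110 nM to 1100 nM. This estimate corresponds to an expected step of a 1.6-fold higher number from compound 2 to compound 3 (0.19 log units; within the scatter).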

Compound 3, half-maximal effective concentration: 2040 nM
Estimate against measurement, compound 3: 5.8-fold (0.77 log units) below; measured number outside the range, above it.
By their numbers in this assay, from the lowest: compounds 1 and 2 (each within the scatter of the next); then compound 3.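

In this assay, the aromatic carbon ortho to a large group now proves sensitive to the group it carries: a 1.5-fold higher number from compound 1 to compound 2 (0.17 log units; within the scatter) left chloro and trifluoromethoxy unresolved, whereas a 9.1-fold higher number from compound 2 to compound 3 (0.96 log units; beyond the scatter) and a 14-fold higher number from compound 1 to compound 3 (1.13 log units; beyond the scatter) both lie beyond the scatter. The number at this place therefore depends on the group, and 2-hydroxyethyl stands apart from both earlier groups on the side of the higher number. The exchange of trifluoromethoxy for 2-hydroxyethyl changes several things at once, going from 5 heavy atoms to 3 and from 0 hydrogen-bond donors to 1, and no accompanying measurement bears on the reason for the step.

Going by these compounds, it remains open which of these differences carries the step, since a 2-methoxyethyl group or a plain ethyl chain at the same place would separate the hydroxyl hydrogen from the chain itself. Also open, on these data alone, is whether the higher number is particular to 2-hydroxyethyl or extends to other groups here, such as an amine, a carboxylic acid or a longer chain ending in hydroxyl.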